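The source may hold more compounds than are shown below. What is called first, only, known or untested is meant among the compounds shown, and "the series" means these compounds.

Measured so far in an in vitro functional assay on cells for agonist activity at Bombesin receptor subtype-3 (Mus musculus), read by luminescence and calcium flux; a lower number here means that less compound is needed, a higher number that more compound is needed for the effect:
Compound 1 `O=C(O)c1ccccc1-c1ccc(CCc2ncc(Cc3cccc(Cl)c3)[nH]2)cc1` gives 31 nM.
Compound 2 `O=C(O)c1ccccc1-c1ccc(CCc2ncc(-c3ccccc3)[nH]2)cc1` gives 872 nM.
Compound 3 `CC(C)(C)c1cnc(CCc2ccc(-c3ccccc3C(=O)O)cc2)[nH]1` gives 2750 nM.

Compound 1 has the lowest number of the three in this assay. Compound 4 `O=C(O)c1ccccc1-c1ccc(CCc2ncc(CCc3ccccc3)[nH]2)cc1` differs from compound 1 in one place: benzyl in place of 3-chlorophenyl on a saturated chain carbon bound to an aromatic carbon, so that, read one bond further out, 3-chlorobenzyl becomes phenethyl. Within the data shown here, two measured steps bear on this, as both also replace the 3-chlorobenzyl of compound 1: a 28-fold higher number from compound 1 to compound 2 (1.45 log units; beyond the scatter) and an 89-fold higher number from compound 1 to compound 3 (1.95 log units; beyond the scatter). Both raised the number strongly. Compound 4 still carries a six-membered aromatic ring of carbon only, unlike compound 3, but no chlorine. A rise in this assay beyond the scatter is therefore expected, though smaller than either step. Compound 4 is estimated at 150 nM, between 40 nM and 600 nM. This corresponds to an expected step of a 4.8-fold higher number from compound 1 to compound 4 (0.68 log units; beyond the scatter).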

Compound 4, half-maximal effective concentration: 174 nM
Estimate against measurement, compound 4: 1.2-fold (0.06 log units) below; the measured number falls inside the stated range.
By their numbers in this assay, from the lowest: compound 1; then compound 4; then compound 2; then compound 3.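

In this assay, phenethyl on this aromatic carbon does much better than the two other replacements, with a 16-fold lower number from compound 3 to compound 4 (1.20 log units; beyond the scatter) and a 5.0-fold lower number from compound 2 to compound 4 (0.70 log units; beyond the scatter), yet it does not match 3-chlorobenzyl, with a 5.6-fold higher number from compound 1 to compound 4 (0.75 log units; beyond the scatter). Among these four compounds, then, the two groups that reach their ring through a saturated chain give lower numbers than phenyl or tert-butyl. No measurement offered here explains this ordering.

Going by these compounds, the change from 3-chlorobenzyl to phenethyl removes the chlorine and lengthens the chain together, so the share of each remains open. Plain benzyl and 3-chlorophenethyl at this place would separate the two.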